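The source may hold more compounds than are shown below. What is called first, only, known or untested is meant among the compounds shown, and "the series" means these compounds.

Values measured in a functional assay on U-373MG ATCC cells for inhibition, with U373 MG (Homo sapiens) as the target, read by MTT assay, with a stated time of 7 days (a higher number here means a weaker inhibitor of growth, a lower number a stronger inhibitor of growth), are as follows.
- compound 1 `NC(=O)c1ncn2c(=O)n(C(c3ccccc3)c3ccccc3)nnc12` gives > 50000 nM as a limit
- compound 2 `NC(=O)c1nc[nH]c1N/N=N/Cc1ccccc1` gives > 50000 nM as a limit

In this assay compound 2 stands at > 50000 nM, which is a limit of the assay and not a number. Both measured compounds share the same reading, (the limit of > 50000 nM in this assay, at which 2 of the 2 values shown sit), so they cannot be placed in any order.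

Compound 3 `NC(=O)c1nc[nH]c1N/N=N/Cc1ccsc1` differs from compound 2 in one place, with thiophen-3-yl in place of phenyl on a saturated chain carbon bound to a double-bonded nitrogen as the whole change. For the measured compounds named here, no measured pair of compounds shows what a change of this kind does. In this assay no step beyond the usual scatter is expected in either direction, and the most likely report for compound 3 is another limit. The expected size of the change is a number no higher from compound 2 to compound 3 (the limit leaves the size open) on this estimate. Compound 3 is estimated at 50000 nM as the expected value, with a range from 20000 nM to 100000 nM as the expected spread.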

Compound 3, concentration for 50% growth inhibition: > 50000 nM
Compound 3: only a limit was reported; the forecaster's own chance of this, stated with the estimate: 75%; the middle value sits exactly at the limit.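

In this assay compound 3 gives > 50000 nM, which is a limit of the assay and not a number. No step from compound 2 to compound 3 can be read, because both stand at the same reading: the limit of > 50000 nM in this assay, at which 3 of the 3 values shown sit.

The compounds shown leave open how potent each one truly is, and whether thiophen-3-yl in place of phenyl makes any difference.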